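Series notes: chloro in place of trifluoromethyl

The source may hold more compounds than are shown below. What is called first, only, known or untested is meant among the compounds shown, and "the series" means these compounds.

Measured compounds:
Compound 1, `O=C1COc2ccc(NC(=O)C3CCN(c4cccc(Br)c4)CC3)cc2N1`, in a functional assay for antagonist activity at transient receptor potential cation channel subfamily V member 1 (Homo sapiens), read by FLIPR and calcium flux (a lower number here means a stronger inhibitor, a higher number a weaker inhibitor), gives 330 nM.
Compound 2, `O=C1COc2ccc(NC(=O)C3CCN(c4cccc(Cl)c4)CC3)cc2N1`, in this assay gives 190 nM.
Compound 3, `O=C1COc2ccc(NC(=O)C3CCN(c4ccccc4C(F)(F)F)CC3)cc2N1`, in this assay gives 380 nM.

Compound 3 has the highest number of the three, but its steps to the other two are small: a 1.2-fold higher number from compound 1 to compound 3 (0.06 log units; within the scatter) and a 2.0-fold higher number from compound 2 to compound 3 (0.30 log units; within the scatter). Compound 4, `O=C1COc2ccc(NC(=O)C3CCN(c4ccccc4Cl)CC3)cc2N1`, differs from compound 3 by chloro in place of trifluoromethyl on an aromatic carbon. Going by the values given here, no measured pair exchanges trifluoromethyl for chloro, so the step has no direct precedent. The closest comparison is a halogen exchange on the same ring position class, a 1.7-fold lower number from compound 1 to compound 2 (0.24 log units; within the scatter), which stayed within scatter, and all three aryl variants so far cluster closely. For compound 4 no step beyond the scatter is therefore expected: a 1.4-fold lower number from compound 3 to compound 4 (0.13 log units; within the scatter). Compound 4 is estimated at 280 nM, with a range from 100 nM to 800 nM.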

Compound 4, half-maximal inhibitory concentration: 220 nM
The estimate for compound 4 lay 1.3-fold (0.10 log units) above the measured number; measured number inside the range.
By their numbers in this assay, from the lowest: compounds 2, 4, 1 and 3 (each within the scatter of the next).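

In this assay chloro can replace trifluoromethyl on the aromatic carbon ortho to a large group without leaving the scatter (a 1.7-fold lower number from compound 3 to compound 4 (0.24 log units; within the scatter)). The 2-chlorophenyl compound also stays within the scatter of the 3-chlorophenyl compound (a 1.2-fold higher number from compound 2 to compound 4 (0.06 log units; within the scatter)) and the 3-bromophenyl compound (a 1.5-fold lower number from compound 1 to compound 4 (0.18 log units; within the scatter)), so these aryl exchanges do not separate the four compounds. No supporting data explain this flat response. Still open, on these data alone, is whether an amine or a carboxylic acid at this position, or an unsubstituted phenyl, would give a step beyond the scatter.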